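A few compounds are considered here, and "the series" means these few. Any claim that something is new, unique, unknown or untested is made for them only; others in the source may bear on it.

Measured compounds:
compound 1 `COc1cccc([C@]2(CO)NC[C@@H](O)[C@@H]2O)c1`
compound 2 `COc1cccc([C@@]2(CO)NC[C@H](O)[C@H]2O)c1`
compound 3 `COc1ccc([C@]2(CO)NC[C@@H](O)[C@@H]2O)cc1OC`

In an assay on isolated protein for inhibition of alpha-mannosidase (Canavalia ensiformis), tested at 1000 uM (on this read-out higher numbers stand for more inhibition at the one concentration tested (going by the name of the read-out) and lower numbers for less inhibition), compound 1 gives 0%. Compound 2 gives 0% in this assay, and compound 3 gives 0%. Compound 3 therefore stands level with compounds 1 and 2 at the digits shown; the step of no change at the digits printed from compound 1 to compound 3 (within the scatter) did not move the read-out.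

Compound 4 `COc1ccc([C@@]2(CO)NC[C@H](O)[C@H]2O)cc1OC` differs from compound 3 in this way:
the two compounds have the same atoms and bonds and differ only in configuration as drawn: 3 of 3 stereo elements differ (all stereocentres are inverted: mirror images); a stereocentre at a saturated ring carbon is drawn R in compound 3 and S in compound 4; a stereocentre at a saturated ring carbon is drawn R in compound 3 and S in compound 4; a stereocentre at a saturated ring carbon is drawn R in compound 3 and S in compound 4

For the measured compounds named here, the one measured step of the same kind is no change at the digits printed from compound 1 to compound 2 (within the scatter), a pair whose difference rests only on (the fact that compounds 1 and 2 differ only in the configuration as drawn). That step stayed within the scatter, so the step from compound 3 to compound 4 is expected to show no change beyond the scatter: no change at the digits printed from compound 3 to compound 4 (within the scatter). Compound 4 is estimated at 0%, within a range from 0% to 10%.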

Compound 4, a percentage reported as inhibition, at one concentration (the size of the read-out at that concentration, not a potency): 0%
For compound 4 middle estimate and measured number coincide at the digits printed, and the stated range covers the measured number.
By their numbers in this assay, from the lowest: compounds 1, 2, 3 and 4 (each within the scatter of the next).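

In this assay, inverting all three stereocentres in the methoxy-substituted series gives no change at the digits printed from compound 3 to compound 4 (within the scatter). The mirror-image change therefore reads the same on a second pair of compounds and is not particular to compounds 1 and 2. The added methoxy also gives no change at the digits printed from compound 2 to compound 4 (within the scatter), so this change now reads the same in both configurations: the same change on two cores in this assay, no change at the digits printed (within the scatter) from compound 1 to compound 3 and no change at the digits printed (within the scatter) from compound 2 to compound 4, 0 percentage points apart, within the scatter of two such steps.

With all four compounds level, neither change can be ranked at this single concentration. On these data alone, whether an amine or a carboxylic acid in place of methoxy would lift the read-out remains open.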